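This account rests on a few compounds, and the source may have more. Where it says the series, first, only, none or still open, it means among the compounds named here.

Measured so far:
- compound 1, `CCOC(=O)c1cnc2ccc(-c3cccc(N)c3)cc2c1`, gives > 7400 nM in a functional assay on RD cells (Homo sapiens) for inhibition, read by luminescence and ATP content, with a stated time of 72 h; on this read-out lower numbers stand for higher toxicity in this test and higher numbers for lower toxicity in this test
- compound 2, `Cc1ccc(-c2ccc3ncc(-c4noc(C)n4)cc3c2)cc1`, gives > 7400 nM in this assay
- compound 3, `CCc1nc(-c2cnc3ccc(-c4cccc(N)c4)cc3c2)no1`, gives > 7400 nM in this assay

Each of these three values is a limit of the assay rather than a number, a point at which all three values sit (the limit of > 7400 nM in this assay, at which 3 of the 3 values shown sit). Compound 3 therefore stands at that limit, and so do the two other compounds shown. Within the data shown here, the one measured step that connects two of them, a step that the two limits leave unreadable from compound 1 to compound 3, is unreadable, since both of its ends are limits.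

Compound 4, `CCc1nc(-c2cnc3ccc(-c4ccc(C)cc4)cc3c2)no1`, differs from compound 3 in one place: 4-methylphenyl in place of 3-aminophenyl on an aromatic carbon. Among the measured compounds shown here, no measured step covers this exchange directly. Compound 2 also carries a 4-methylphenyl group and sits at the limit, which is the only indirect hint the data give.

With nothing readable to build on, no step beyond the scatter is expected, so a step that the limit leaves unreadable from compound 3 to compound 4 is the estimate. For compound 4, the expected value is 10000 nM, within a range from 5000 nM to 30000 nM, and most likely the assay will again report only a limit.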

Compound 4, half-maximal cytotoxic concentration: > 7400 nM
Compound 4 gave a limit, no number; the forecaster's own chance of this, stated with the estimate: 85%; the middle value is on the limit's open side.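

Compound 4 gives only a limit, so the steps from compound 3 and from compound 2 to compound 4 cannot be read, because every value sits at the same limit: the limit of > 7400 nM in this assay, at which 4 of the 4 values shown sit.

The compounds shown leave open whether any of these exchanges changes the result in this assay, and by how much.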